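A few compounds are considered here, and "the series" means these few. Any claim that something is new, unique, unknown or untested is made for them only; others in the source may bear on it.

Measured compounds:

Compound 1 `CCN(CC)C(=O)c1nc2ccccc2n1Cc1ccccc1`: in an assay on HEK293 cells for displacement of a labelled ligand from Translocator protein (Homo sapiens), read by scintillation counting, with a stated time of 90 min (a lower number here means a stronger inhibitor, a higher number a weaker inhibitor), compound 1 gives > 10000 nM, a limit of the assay and not a number.
Compound 2 `CCN(CC)C(=O)c1cc2cc(C)ccc2n1Cc1ccc(OCc2ccccc2)cc1`: in this assay compound 2 gives > 10000 nM, again a limit.
Compound 3 `CCN(CC)C(=O)c1cc2cc(C)ccc2n1Cc1ccc(O)cc1`: in this assay compound 3 gives > 10000 nM, also a limit.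

Compound 3 therefore stands at the limit of this assay, and so do the other two values in hand (the limit of > 10000 nM in this assay, at which 3 of the 3 values shown sit). For the measured compounds named here, the only step between measured compounds, a step that the two limits leave unreadable from compound 2 to compound 3, has no readable size, as both of its ends sit at that same limit (the limit of > 10000 nM in this assay, at which 3 of the 3 values shown sit). Nothing measured in this series gives a direction or a size for any structural change.

Compound 4 `CCN(CC)C(=O)c1cc2cc(C)ccc2n1Cc1cn[nH]n1` differs from compound 3 by 2H-1,2,3-triazol-4-yl in place of 4-hydroxyphenyl on a saturated chain carbon bound to an aromatic nitrogen. Going by the values given here, no measured step bears on this exchange; the one step in hand is unreadable, and the change from 4-hydroxybenzyl to (2H-1,2,3-triazol-4-yl)methyl has no counterpart among the measured pairs. With all three measured compounds at the limit, compound 4 is expected to return a limit as well, so that the step that the limit leaves unreadable from compound 3 to compound 4 is expected to be nothing readable. For compound 4 in this assay the estimate is 20000 nM, with a range from 3000 nM to 100000 nM.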

Compound 4, inhibition constant: > 10000 nM
Compound 4: no number, only a limit (the forecaster's own chance of this, stated with the estimate: 80%); the middle value does not contradict the limit.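

No size can be read for the exchange of 4-hydroxyphenyl for 2H-1,2,3-triazol-4-yl between compound 3 and compound 4, as both values are limits and not numbers: the limit of > 10000 nM in this assay, at which 4 of the 4 values shown sit. The compounds shown leave open whether any structural change on the shared core gives a readable number in this assay at all.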